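The compounds below may be only part of what the source reports. "The series", "measured", "known", "first", "only" and "open" are said of these compounds alone.

Of the compounds shown here, three built on one shared core have been read in an ADME assay on Vero cells (Chlorocebus sabaeus) for cytotoxicity, read by resazurin assay, with a stated time of 72 h; on this read-out higher numbers stand for weaker inhibition and lower numbers for stronger inhibition. Compound 1 (`COc1ccc(C(=O)CCN2CCN(c3ccc(F)cc3)CC2)cc1`) gives 55000 nM and compound 2 (`O=C(CCN1CCN(c2ccc(F)cc2)CC1)c1ccc(Br)cc1`) gives 99500 nM, while compound 3 (`O=C(CCN1CCN(c2ccc(F)cc2)CC1)c1ccc(F)c(Br)c1`) gives 352000 nM as the highest number of the three, which makes it the weakest inhibitor of these cells so far.

The next compound, compound 4 (`O=C(CCN1CCN(c2ccc(F)cc2)CC1)c1ccc(F)c(F)c1`), alters compound 3 in one place. The change is fluoro in place of bromo on an aromatic carbon and in words it is fluoro in place of bromo on an aromatic carbon, which turns 3-bromo-4-fluorophenyl into 3,4-difluorophenyl.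

Among the compounds with values here, no measured pair makes this exact swap. The closest evidence comes from the steps that introduce the 3-bromo-4-fluorophenyl group: a 3.5-fold higher number from compound 2 to compound 3 (0.55 log units; beyond the scatter) and a 6.4-fold higher number from compound 1 to compound 3 (0.81 log units; beyond the scatter) are both modest and both rise. By contrast, a 1.8-fold higher number from compound 1 to compound 2 (0.26 log units; within the scatter) stays within the scatter and shows that a bromo is not always tied to a rise. None of these steps isolates the bromo of compound 3, so the guidance is weak. A small move towards a lower number seems the likeliest outcome. The expected step is a 1.6-fold lower number from compound 3 to compound 4 (0.20 log units; within the scatter) and it may not exceed the scatter. For compound 4 the estimated value is 220000 nM with 80000 nM and 500000 nM as the expected ends of its range.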

Compound 4, half-maximal inhibitory concentration: 385000 nM
Compound 4: middle estimate off by 1.8-fold (0.24 log units), on the low side; low and high end bracket the measured number.
By their numbers in this assay, from the lowest: compounds 1 and 2 (each within the scatter of the next); then compounds 3 and 4 (each within the scatter of the next).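

In this assay, within the data shown here, the swap of bromo for fluoro, on an aromatic carbon ortho to a fluoro group and meta to a large group, gives a 1.1-fold higher number from compound 3 to compound 4 (0.04 log units; within the scatter), the first reading of this exchange on its own, and at this place the read-out does not separate the two groups. Steps from the other two compounds add to this: 3,4-difluorophenyl in place of 4-bromophenyl gives a 3.9-fold higher number from compound 2 to compound 4 (0.59 log units; beyond the scatter), and 3,4-difluorophenyl in place of 4-methoxyphenyl gives a 7.0-fold higher number from compound 1 to compound 4 (0.85 log units; beyond the scatter), so the rise seen earlier with 3-bromo-4-fluorophenyl also appears with no bromo in the molecule. No measurement here offers a reason for any of these readings.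

The compounds shown leave open whether this insensitivity holds for quite different groups at the same place, such as a nitrile, an amine or a carboxylic acid, or for a plain hydrogen there. They also leave open how much of the rise belongs to the fluoro that compound 3 and compound 4 share, since that fluoro never changes alone.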